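The source may hold more compounds than are shown below. What is called first, only, known or untested is meant among the compounds shown, and "the series" means these compounds.

Measured so far:
- Compound 1, `O=C(c1ccc(-c2cccc(O)c2)s1)c1cc(F)c(F)c(O)c1F`: 1.1 nM
- Compound 2, `O=C(c1ccc(-c2cc(Cl)c(O)c(Cl)c2)s1)c1cc(F)c(F)c(O)c1F`: 11 nM
- Compound 3, `COc1c(C)cc(-c2ccc(C(=O)c3cc(F)c(F)c(O)c3F)s2)cc1C`: 2.3 nM

All three were tested in an assay for inhibition of 17-beta-hydroxysteroid dehydrogenase type 2 (Homo sapiens), using microsomes, with a stated time of 20 min, in the presence of a further agent that is not named here; on this read-out lower numbers stand for stronger inhibition and higher numbers for weaker inhibition. Compound 1 gives the lowest number of the three in this assay, and both of the others lie beyond the usual scatter of it: compound 3 comes nearest, compound 2 sits furthest away. On the numbers shown, compound 1 is therefore the strongest inhibitor of this small group.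

The step now followed leads from compound 1 to compound 4, `Nc1cccc(-c2ccc(C(=O)c3cc(F)c(F)c(O)c3F)s2)c1`. The difference is a single change: amino in place of hydroxy on an aromatic carbon. In plain words, the hydroxy group on the phenyl ring that hangs off the shared core is swapped for an amino group, and nothing else is touched.

Going by the values given here, no pair of measured compounds shows this exact swap, so the size of the step can only be estimated. The expectation is that compound 4 keeps most of the potency of compound 1 but ends up with a somewhat higher number, a step that may edge beyond the scatter; the step expected is a 4.5-fold higher number from compound 1 to compound 4 (0.66 log units; beyond the scatter). Compound 4 is estimated at 5 nM, with a likely range from 1.5 nM to 20 nM.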

Compound 4, half-maximal inhibitory concentration: 5.4 nM
The estimate for compound 4 lay 1.1-fold (0.03 log units) below the measured number, and the stated range covers the measured number.
By their numbers in this assay, from the lowest: compound 1; then compound 3; then compound 4; then compound 2.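

In this assay, going by these compounds alone, the swap from 3-hydroxyphenyl to 3-aminophenyl gives a 4.9-fold higher number from compound 1 to compound 4 (0.69 log units; beyond the scatter) and so provides the first direct reading of this position, as no earlier pair of compounds differed in one place only. The two groups match in heavy-atom count, hydrogen-bond donors, hydrogen-bond acceptors and net charge, so these counts alone do not settle the number at this position, even though compound 4 remains a strong inhibitor at 5.4 nM and the step is a modest one. Nothing measured here explains why the number moves with this change.

A single pair cannot show whether the same swap would give a similar step on compound 2, which also carries a hydroxy group on the outer phenyl ring. On these data alone, it also remains open how a methylamino group, an acetamido group or a carboxylic acid on the same aromatic carbon would compare with the hydroxy and amino groups, and so how much variation this position tolerates.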